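Sec-butyl for methylimidazolyl on the amide-type nitrogen

The source may report more compounds than this note shows. Statements on the series, on what has been measured and on what is new or still open speak of the compounds shown alone.

Three compounds of the series have numbers in an assay on HEK293 cells for agonist activity at transient receptor potential cation channel subfamily M member 8 (Homo sapiens), read by fluorescence and calcium flux, with a stated time of 15 min; on this read-out higher numbers stand for an effect only at larger amounts of compound and lower numbers for an effect already at smaller amounts. Compound 1 `Cc1ccc(OCC(=O)N(Cc2cccs2)CC(C)C)cc1` gives 900 nM. Compound 2 `Cc1ccc(OCC(=O)N(Cc2cccs2)c2ccn[nH]2)cc1` gives 0.2 nM. Compound 3 `Cc1ccc(OCC(=O)N(Cc2cccs2)c2nccn2C)cc1` gives 1790 nM, the highest of the three numbers; its nearest neighbour is compound 1, with a 2.0-fold higher number from compound 1 to compound 3 (0.30 log units; within the scatter), and its furthest is compound 2, with a 9000-fold higher number from compound 2 to compound 3 (3.95 log units; beyond the scatter). The two large steps, a 4500-fold lower number from compound 1 to compound 2 (3.65 log units; beyond the scatter) and a 9000-fold higher number from compound 2 to compound 3 (3.95 log units; beyond the scatter), both involve compound 2 only; between compound 1 and compound 3 the series is flat.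

Compound 4 `CCC(C)N(Cc1cccs1)C(=O)COc1ccc(C)cc1` has not yet been measured. It differs from compound 3 in one place: sec-butyl in place of 1-methyl-1H-imidazol-2-yl on an amide-type nitrogen. The step that bears on this is a 2.0-fold higher number from compound 1 to compound 3 (0.30 log units; within the scatter), where isobutyl, a chain of the same size as sec-butyl, stood on the same amide-type nitrogen; that step stayed within the scatter. Nothing measured separates sec-butyl from isobutyl. For compound 4 in this assay a step of about a 1.8-fold lower number from compound 3 to compound 4 (0.25 log units; within the scatter) is therefore expected, which is no change beyond the scatter. The number for compound 4 is estimated at 1000 nM, with a range from 300 nM to 3500 nM.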

Compound 4, half-maximal effective concentration: 2000 nM
Compound 4: the middle estimate sits 2.0-fold (0.30 log units) below what was measured; the range from low to high includes it.
By their numbers in this assay, from the lowest: compound 2; then compounds 1, 3 and 4 (each within the scatter of the next, the first and the last beyond it).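

In this assay the result of a 1.1-fold higher number from compound 3 to compound 4 (0.05 log units; within the scatter) shows that 1-methyl-1H-imidazol-2-yl on the amide-type nitrogen cannot be told apart from sec-butyl, which has no ring and no hydrogen-bond acceptors, so the mere presence of this five-membered aromatic ring with its two hetero atoms does not set a compound apart here. Among these compounds, the two branched chains do separate, though only modestly, with a 2.2-fold higher number from compound 1 to compound 4 (0.35 log units; beyond the scatter) as the first step that lies beyond the scatter without involving compound 2. The step of a 10000-fold higher number from compound 2 to compound 4 (4.00 log units; beyond the scatter) leaves 1H-pyrazol-5-yl alone at this position, since a second saturated chain joins the ring of compound 3 far from compound 2 on this read-out.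

Still open, going by these compounds, is whether a 1-methyl-1H-pyrazol-5-yl or an unmethylated 1H-imidazol-2-yl on the same nitrogen would read with compound 2 or with compounds 1, 3 and 4, which would show whether the ring nitrogen hydrogen or the arrangement of the ring atoms tracks the low number. No supporting measurement is available to explain any of these steps.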